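The compounds below may be only part of what the source reports. "The series", "measured", "known", "first", "only" and "open" are said of these compounds alone.

Working notes on a series of hydrazone-linked compounds read in an ADME assay on NIH3T3 cells (Mus musculus) for cytotoxicity, read by MTT assay, with a stated time of 24 h; on this read-out higher numbers stand for weaker inhibition and lower numbers for stronger inhibition. The series comprises compound 1 `Cc1ccc(-c2cs/c(=N/NC(=O)CSc3nnnn3-c3ccccc3)n2-c2ccccc2)cc1`, compound 2 `Cc1nnc(SCC(=O)N/N=c2/scc(-c3ccc([N+](=O)[O-])cc3)n2-c2ccccc2)s1`, compound 3 `Cn1cnnc1SCC(=O)N/N=c1/scc(-c2ccc(Br)cc2)n1-c1ccccc1` and, not yet measured, compound 4 `O=C(CSc1nnnn1-c1ccccc1)N/N=c1/scc(-c2ccc(Cl)cc2)n1-c1ccccc1`. In this assay, going by the values given here, compound 2 gives 177 ug/mL and compound 3 gives 58.3 ug/mL; no single-point step links these two to compound 1. For compound 1 only a limit is known, as in this assay compound 1 gives > 500 ug/mL, the upper limit of the measurement (the limit of > 500 ug/mL in this assay, at which 1 of the 3 values shown sits).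

The step from compound 1 to compound 4 is chloro in place of methyl on an aromatic carbon. Among the compounds with values here, no measured step of this kind exists in the set, so the expected step from compound 1 to compound 4 in this assay is estimated to be small, with a slight lean toward stronger inhibition, at an at least 1.4-fold lower number from compound 1 to compound 4 (0.15 log units; that floor lies within the scatter). Compound 4 is therefore expected to give about 350 ug/mL, in the range 120 ug/mL to 600 ug/mL.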

Compound 4, half-maximal inhibitory concentration: 313 ug/mL
Compound 4: middle estimate off by 1.1-fold (0.05 log units), on the high side; the range from low to high includes it.
By their numbers in this assay, from the lowest: compound 3; then compounds 2 and 4 (each within the scatter of the next). At a limit, above all of these: compound 1.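

In this assay, going by these compounds alone, the change from 4-methylphenyl to 4-chlorophenyl, para to a large group, gives the only readable step (an at least 1.5-fold lower number from compound 1 to compound 4 (0.20 log units; that floor lies within the scatter)). That floor lies within the scatter, so this change shows no step beyond it so far, although the true step may be larger. As far as these compounds go, whether an amine or a carboxylic acid at this place would move the number beyond the scatter remains open. The full size of this step also stays open, because compound 1 is held only as a limit: the limit of > 500 ug/mL in this assay, at which 1 of the 4 values shown sits.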